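Replacing 3-chlorophenyl with 2-phenylethenyl in compound 1

The source may report more compounds than this note shows. Statements on the series, on what has been measured and on what is new or still open speak of the compounds shown alone.

Compound 1 `O=C1C(=Cc2cccc(Cl)c2)C(=O)N(c2ccc(Cl)cc2)N1c1ccc(Cl)cc1`: 18300 nM
Compound 2 `CC(=C1C(=O)N(c2ccc(Cl)cc2)N(c2ccc(Cl)cc2)C1=O)c1ccc(O)cc1`: 76500 nM

These values come from a functional assay on MCF7 cells (Homo sapiens) for cytotoxicity, read by MTT assay, with a stated time of 72 h; a lower number here means a stronger inhibitor, a higher number a weaker inhibitor. Compound 1 holds the lower of the two numbers at 18300 nM, and the gap to compound 2, which gives 76500 nM, lies beyond the scatter. Compound 3 `O=C1C(=C/C=C/c2ccccc2)C(=O)N(c2ccc(Cl)cc2)N1c1ccc(Cl)cc1` carries 2-phenylethenyl in place of 3-chlorophenyl on a double-bonded chain carbon bound to a double-bonded ring carbon. For the measured compounds named here, no measured pair isolates this change, so no shift beyond the scatter is expected in this assay. The expected change is a 1.1-fold higher number from compound 1 to compound 3 (0.04 log units; within the scatter). For compound 3 the estimate is 20000 nM, with an expected range of 7000 nM to 60000 nM.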

Compound 3, half-maximal inhibitory concentration: 9400 nM
The estimate for compound 3 lay 2.1-fold (0.33 log units) above the measured number, and the stated range covers the measured number.
By their numbers in this assay, from the lowest: compounds 3 and 1 (each within the scatter of the next); then compound 2.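

In this assay, 2-phenylethenyl in place of 3-chlorophenyl on a double-bonded chain carbon bound to a double-bonded ring carbon gives a 1.9-fold lower number from compound 1 to compound 3 (0.29 log units; within the scatter), so the step stays within the scatter. This place therefore takes a group with no chlorine and an added double bond outside aromatic rings without a shift beyond the scatter. No evidence at hand bears on this result. The compounds shown leave open whether a saturated 2-phenylethyl chain would behave the same way at this place. They also leave open what an amine or a carboxylic acid on the phenyl ring would do.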